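This account rests on a few compounds, and the source may have more. Where it says the series, first, only, none or still open, it means among the compounds named here.

Three measured compounds share one core and differ only in the group on the pyrazole-type ring. Compound 1 `CNC(=O)c1cc(C)n(Cc2cc(Cl)ccc2OCc2ccccc2)n1` gives in a physicochemical assay for lipophilicity, at pH 7.4 (a higher number here means a more lipophilic compound, a lower number a more polar compound), a reading of > 3.7, which is a limit of the assay rather than a number. Compound 2 `Cc1cc(C(=O)NCc2cccnc2)nn1Cc1cc(Cl)ccc1OCc1ccccc1` likewise gives in this assay a reading of > 3.7, again a limit and not a number. Going by the values given here, compound 3 `Cc1cc(NC(=O)C2CCCC2)nn1Cc1cc(Cl)ccc1OCc1ccccc1` gives in this assay a value of 3.5, the only actual number among the three, while the other two sit at the limit of > 3.7 in this assay, at which 2 of the 3 values shown sit. The steps to compound 3 are therefore known only as floors: a number at least 0.20 log units lower from compound 1 to compound 3 (that floor lies within the scatter) and a number at least 0.20 log units lower from compound 2 to compound 3 (that floor lies within the scatter).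

Compound 4 `Cc1cc(NC(=O)O[C@H]2CCOC2)nn1Cc1cc(Cl)ccc1OCc1ccccc1` has not yet been measured. It differs from compound 3 in one place: (oxolan-3-yl)oxy in place of cyclopentyl on a carbonyl carbon. Among the compounds with values here, none of the measured steps touches this part of the molecule, so no step directly speaks to it; all three measured changes sit on the nitrogen side of the amide, whereas here the carbonyl side changes and a carbamate results. Given that the entering group brings two hydrogen-bond acceptors where the leaving cyclopentyl brought none, the expected direction in this assay is downward, with a step of roughly a number 1.00 log units lower from compound 3 to compound 4 (beyond the scatter) expected. Compound 4 is accordingly estimated at 2.5, between 1.9 and 3.1.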

Compound 4, distribution coefficient: 2.7
Estimate against measurement, compound 4: 0.20 log units below; low and high end bracket the measured number.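

Going by these compounds alone, this is the first measured change on the carbonyl side of the amide: on a carbonyl carbon, (oxolan-3-yl)oxy, with 2 hydrogen-bond acceptors, takes the place of cyclopentyl, with 0, and in this assay this gives a number 0.80 log units lower from compound 3 to compound 4 (beyond the scatter). Unlike the earlier steps to compound 3, which were only floors within the scatter, this one has a readable size, and the new carbamate also stands clear of the two carbamoyl compounds, with a number at least 1.00 log units lower from compound 2 to compound 4 (beyond the scatter) and a number at least 1.00 log units lower from compound 1 to compound 4 (beyond the scatter). Those last two steps remain floors because the readings of compound 1 and compound 2 are limits of the assay and not numbers: the limit of > 3.7 in this assay, at which 2 of the 4 values shown sit.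

The compounds shown leave open which of the two oxygens of (oxolan-3-yl)oxy accounts for the step, a question that cyclopentyloxy or oxolan-3-yl on the same carbonyl carbon would address. Within the data shown here, also open are whether the defined stereocentre matters, since only one form of the group appears here, and how a urea made with an amine such as pyrrolidine would read in this assay.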